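The source may hold more compounds than are shown below. What is called first, only, known or untested is meant among the compounds shown, and "the series" means these compounds.

Compound 2 `COc1ccccc1OC(C)C1=NCCN1` is the starting point of this step. In an assay on CHO cells for displacement of a labelled ligand from Alpha-2B adrenergic receptor (Homo sapiens) (a lower number here means a stronger inhibitor, a higher number a weaker inhibitor), compound 2 gives 871 nM. Among the measured compounds shown here, its only measured relative is compound 1 `C=C(C)c1ccccc1OC(C)C1=NCCN1`, which in this assay gives 871 nM; the two sit level, and the step of no change at the digits printed from compound 1 to compound 2 (within the scatter) amounts to nothing beyond the scatter. Compound 3 `CC(Oc1ccccc1S(C)(=O)=O)C1=NCCN1` carries the same shared core and changes one group: methylsulfonyl in place of methoxy on an aromatic carbon. Just one measured step bears on this change. It swapped the group on the same aromatic carbon once before, a methoxy in place of a 1-methylethenyl, and the potency stayed put, as no change at the digits printed from compound 1 to compound 2 (within the scatter) shows. For the measured compounds named here, nothing measured tells how a methylsulfonyl fares at this place, so the one precedent, a swap that moved nothing, is all there is to lean on. For compound 3 the expected step in this assay is therefore small, leaning slightly toward weaker binding and quite possibly inside the scatter: a 1.5-fold higher number from compound 2 to compound 3 (0.17 log units; within the scatter). Compound 3 is thus estimated at 1300 nM, with a range from 400 nM to 4500 nM.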

Compound 3, inhibition constant: 51300 nM
Beside the measured number, compound 3's estimate is 39-fold (1.60 log units) below it; the whole stated range lies below it.
By their numbers in this assay, from the lowest: compounds 1 and 2 (each within the scatter of the next); then compound 3.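

In this assay this aromatic carbon turns out not to accept every group alike: methylsulfonyl in place of methoxy gives a 59-fold higher number from compound 2 to compound 3 (1.77 log units; beyond the scatter) and methylsulfonyl in place of 1-methylethenyl gives a 59-fold higher number from compound 1 to compound 3 (1.77 log units; beyond the scatter). The earlier swap at this carbon, between 1-methylethenyl and methoxy, moved nothing beyond the scatter, so that single step could not show that the group here matters; compound 3 shows that it can matter a great deal, and of the three groups at this place, methylsulfonyl alone stands apart. Nothing available explains why this group costs so much binding.

The compounds shown leave open whether the loss goes with the sulfur, with the oxygens on it, or only with the complete methylsulfonyl group, and a methylthio group, which keeps the sulfur and the methyl but lacks the oxygens, would help to separate these. They also leave open how an amine or a carboxylic acid would fare on this same aromatic carbon, and whether methylsulfonyl would cost as much on another carbon of the ring.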